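Piperidine sulfonamides: amide for azepane at the ring carbon

A few compounds are considered here, and "the series" means these few. Any claim that something is new, unique, unknown or untested is made for them only; others in the source may bear on it.

Measured compounds and values:
Compound 1, `Cc1cc(C)c(S(=O)(=O)N2CCC(N3CCCCCC3)CC2)c(C)c1`, gives 5.3 nM in a functional assay on DLD-1 cells (Homo sapiens) for antiproliferative activity, read by CellTiter-Glo, with a stated time of 72 h; on this read-out lower numbers stand for stronger inhibition and higher numbers for weaker inhibition.
Compound 2, `CC1CCN(C2CCN(S(=O)(=O)c3ccc(Br)c(Cl)c3)CC2)CC1`, gives 12 nM in this assay.
Compound 3, `COc1ccc(OC)c(S(=O)(=O)N2CCC(N3CCC(C)CC3)CC2)c1`, gives 4.5 nM in this assay.

Among the three numbers compound 1 stands second highest. Its nearest neighbour is compound 3, whose number is within the scatter of that of compound 1, so no order between the two can be read. Compound 2 sits further away, with a number higher than that of compound 1 beyond the scatter.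

Going by the values given here, no pair of measured compounds differs in a single place, so no step has been measured. Compound 4, `Cc1cc(C)c(S(=O)(=O)N2CCC(C(=O)N3CCC(C)CC3)CC2)c(C)c1`, differs from compound 1 in one place: (4-methylpiperidin-1-yl)carbonyl in place of azepan-1-yl on a saturated ring carbon. Among the compounds with values here, every measured compound carries a saturated amine ring directly on that ring carbon; compound 4 is the first in which a carbonyl stands between the two rings. Within the data shown here, with no measured step to lean on, the expectation is a move toward higher numbers in this assay, beyond the scatter, but uncertain in size.

The estimate for compound 4 in this assay is 80 nM, within a range of 12 nM to 600 nM, which corresponds to an expected step of a 15-fold higher number from compound 1 to compound 4 (1.18 log units; beyond the scatter).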

Compound 4, half-maximal inhibitory concentration: > 5000 nM
Compound 4: a limit, no number; the forecaster's own chance of this, stated with the estimate: 10%; middle value at least 62-fold (1.79 log units) away from the limit.
By their numbers in this assay, from the lowest: compounds 3 and 1 (each within the scatter of the next); then compound 2. At a limit, above all of these: compound 4.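

Going by these compounds alone, on the saturated ring carbon of the core of compound 1, (4-methylpiperidin-1-yl)carbonyl in place of azepan-1-yl gives an at least 940-fold higher number from compound 1 to compound 4 (2.97 log units; beyond the scatter) in this assay, the first measured step at this position and a large one, so the position does not accept every change. Compound 4 stands at > 5000 nM, which is a limit and not a number, and the full size of the step cannot be read: the limit of > 5000 nM in this assay, at which 1 of the 4 values shown sits. The step carries several changes at once, with a carbonyl entering, a seven-membered ring giving way to a six-membered one and a methyl appearing, and this single pair assigns the loss to none of them.

Open, going by these compounds, is whether (4-methylpiperidin-1-yl)methyl, with a methylene in place of the carbonyl, or azepan-1-ylcarbonyl, which keeps the seven-membered ring, would stay near compound 1 or fall as far as compound 4. Also open, on these data alone, is whether the same change has a step of similar size on the sulfonamide parts of compound 2 and compound 3.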